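The source may hold more compounds than are shown below. What is called first, only, known or untested is meant among the compounds shown, and "the series" means these compounds.

Among the compounds with values here, in an assay on LtK cells with ATP-sensitive inward rectifier potassium channel 11 (Homo sapiens) as the target (on this read-out higher numbers stand for an effect only at larger amounts of compound and lower numbers for an effect already at smaller amounts), compound 3 `O=C(Nc1c(C(O)(C(F)(F)F)C(F)(F)F)ccc2ccccc12)c1ccc(Cl)cc1` gives 570 nM, the second highest of the three numbers known. Compound 1 `Cc1ccccc1C(=O)Nc1c(C(O)(C(F)(F)F)C(F)(F)F)ccc2ccccc12` gives 5550 nM and compound 2 `O=C(Nc1c(C(O)(C(F)(F)F)C(F)(F)F)ccc2ccccc12)c1ccc(F)cc1` gives 70 nM. The change a 79-fold lower number from compound 1 to compound 2 (1.90 log units; beyond the scatter) was large, while a 9.7-fold lower number from compound 1 to compound 3 (0.99 log units; beyond the scatter) and an 8.1-fold higher number from compound 2 to compound 3 (0.91 log units; beyond the scatter) were modest. Compound 4 `O=C(Nc1c(C(O)(C(F)(F)F)C(F)(F)F)ccc2ccccc12)c1ccc(Cl)c(Cl)c1` differs from compound 3 by chloro in place of hydrogen on an aromatic carbon. Within the data shown here, no measured step adds a second chloro group, so the three steps bear on this change only loosely; compound 2 and compound 3 show that a halogen change alone moved this assay well beyond the scatter. A small step is therefore expected, in either direction, a 1.2-fold higher number from compound 3 to compound 4 (0.09 log units; within the scatter). Compound 4 is estimated at 700 nM, between 150 nM and 3000 nM.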

Compound 4, half-maximal effective concentration: 194 nM
Compound 4: middle estimate off by 3.6-fold (0.56 log units), on the high side; the measured number falls inside the stated range.
By their numbers in this assay, from the lowest: compound 2; then compound 4; then compound 3; then compound 1.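

In this assay, within the data shown here, the added chloro group, ortho to the existing chloro group, gives a 2.9-fold lower number from compound 3 to compound 4 (0.47 log units; beyond the scatter), so this ring position, untouched by the earlier steps, can change the read-out. The 3,4-dichlorophenyl group still falls short of 4-fluorophenyl, with a 2.8-fold higher number from compound 2 to compound 4 (0.44 log units; beyond the scatter), yet it stays far ahead of 2-methylphenyl, with a 29-fold lower number from compound 1 to compound 4 (1.46 log units; beyond the scatter). Nothing measured here gives a reason for these steps. From the compounds shown here alone, whether a fluoro, methoxy or nitrile group would act alike at this position remains open, as does whether the gain depends on the chloro group already present.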